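The compounds below may be only part of what the source reports. "The series", "measured", "known", "first", "only" and "open" are said of these compounds alone.

Measured compounds:
Compound 1, `CC#C[C@H]1CN(S(=O)(=O)c2ccc(N)nc2)CCN1c1ccc(C(=O)NC)cc1`, in an assay on cells (Hepatocyte) for inhibition of glucokinase regulatory protein (Mus musculus), with stated times of 20 min and 40 min; on this read-out lower numbers stand for an effect already at smaller amounts and higher numbers for an effect only at larger amounts of compound: 4050 nM
Compound 2, `CC#C[C@H]1CN(S(=O)(=O)c2ccc(N)nc2)CCN1c1ccc(S(=O)(=O)NCC2CC2)cc1`, in this assay: 271 nM
Compound 3, `CC#C[C@H]1CN(S(=O)(=O)c2ccc(N)nc2)CCN1c1ccc(S(N)(=O)=O)cc1`, in this assay: 37 nM

Compound 3 stands lowest of the three numbers in this assay. Its nearest neighbour is compound 2, reached by a 7.3-fold lower number from compound 2 to compound 3 (0.86 log units; beyond the scatter), and the furthest is compound 1, reached by a 110-fold lower number from compound 1 to compound 3 (2.04 log units; beyond the scatter). Compound 2 itself sits well below compound 1, as a 15-fold lower number from compound 1 to compound 2 (1.17 log units; beyond the scatter) shows.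

Compound 4, `CC#C[C@H]1CN(S(=O)(=O)c2ccc(N)nc2)CCN1c1ccc(S(C)(=N)=O)cc1`, differs from compound 3 in one place: a group of 4 heavy atoms (1 carbon, 1 nitrogen, 1 oxygen, 1 sulfur; no ring) in place of a group of 4 heavy atoms (1 nitrogen, 2 oxygen, 1 sulfur; no ring), on an aromatic carbon.

Going by the values given here, no measured step changes this position in exactly this way. Among the compounds with values here, the steps that bear on it are those that exchange the group on this aromatic carbon: a 110-fold lower number from compound 1 to compound 3 (2.04 log units; beyond the scatter) and a 15-fold lower number from compound 1 to compound 2 (1.17 log units; beyond the scatter) both show that the choice of group here moves the number strongly, while a 7.3-fold lower number from compound 2 to compound 3 (0.86 log units; beyond the scatter) shows that adding carbon to the sulfamoyl nitrogen raises the number by a modest amount. Because a 7.3-fold lower number from compound 2 to compound 3 (0.86 log units; beyond the scatter) shows that carbon on the sulfamoyl nitrogen raises the number and the group entering compound 4 again carries carbon where compound 3 has none, a higher number than that of compound 3 is expected, by a modest step of about a 4.1-fold higher number from compound 3 to compound 4 (0.61 log units; beyond the scatter).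

Compound 4 is therefore expected to give 150 nM in this assay, with a range from 40 nM to 600 nM.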

Compound 4, half-maximal effective concentration: 704 nM
Beside the measured number, compound 4's estimate is 4.7-fold (0.67 log units) below it; the whole stated range lies below it.
By their numbers in this assay, from the lowest: compound 3; then compound 2; then compound 4; then compound 1.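

In this assay, the new group matches sulfamoyl in its counts of heavy atoms, double bonds, hydrogen-bond donors and hydrogen-bond acceptors, yet the exchange still gives a large change, a 19-fold higher number from compound 3 to compound 4 (1.28 log units; beyond the scatter), so these counts alone do not set the number at this aromatic carbon. The smaller new group also gives a higher number than the larger (cyclopropylmethyl)sulfamoyl group, a 2.6-fold higher number from compound 2 to compound 4 (0.41 log units; beyond the scatter), while still improving on methylcarbamoyl, a 5.8-fold lower number from compound 1 to compound 4 (0.76 log units; beyond the scatter), so among these sulfur-bearing groups the number does not follow heavy-atom count. No measurement here accounts for the gap between sulfamoyl and the new group.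

The compounds shown leave open which part of the exchange carries the change: carbon on sulfur in place of a nitrogen, or a nitrogen in place of an oxygen. A methylsulfonyl group, or a sulfamoyl group bearing a single methyl on its nitrogen, at this same position would show how far each alteration alone moves the number.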